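Opening the Epoxide Back to a Chalcone

The compounds below may be only part of what the source reports. "The series", "measured", "known", "first", "only" and "open" are said of these compounds alone.

Compound 3 `COC(=O)c1cc(-c2cccc(NC(=O)c3ccc(C4OC4C(=O)c4ccc(Cl)cc4)cc3)c2)on1` carries a 3-((4-chlorophenyl)carbonyl)oxiran-2-yl group on the shared core. In an ADME assay on Vero cells (Chlorocebus sabaeus) for cytotoxicity, read by MTT assay, with a stated time of 72 h (on this read-out higher numbers stand for lower toxicity in this test and lower numbers for higher toxicity in this test), compound 3 gives only a limit, > 20 ug/mL. Compound 1 `COC(=O)c1cc(-c2cccc(NC(=O)c3ccc(/C=C/C(=O)c4cccc(Cl)c4)cc3)c2)on1` also gives only a limit in this assay, > 2.5 ug/mL. Compound 2 `COC(=O)c1cc(-c2cccc(NC(=O)c3ccc(/C=C/C(=O)c4ccc(OC)cc4OC)cc3)c2)on1` likewise gives only a limit in this assay, > 50 ug/mL. Compound 4 `COC(=O)c1cc(-c2cccc(NC(=O)c3ccc(/C=C/C(=O)c4ccc(Cl)cc4)cc3)c2)on1` differs from compound 3 by 2-((4-chlorophenyl)carbonyl)ethenyl in place of 3-((4-chlorophenyl)carbonyl)oxiran-2-yl on an aromatic carbon. The nearest measured step, a step that the two limits leave unreadable from compound 1 to compound 3, runs between an oxiranyl and an ethenyl linker in the opposite direction, and a step that the two limits leave unreadable from compound 1 to compound 2 is equally unreadable, so neither size nor direction can be read for this change. Compound 4 is therefore expected to stay near the limits seen so far, with a number no higher from compound 3 to compound 4 (the limit leaves the size open). Compound 4 is estimated at 20 ug/mL, within 5 ug/mL to 80 ug/mL.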

Compound 4, half-maximal cytotoxic concentration: > 50 ug/mL
Compound 4: no number, only a limit; the forecaster's own chance of this, stated with the estimate: 60%; middle value at least 2.5-fold (0.39 log units) from the limit.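

In this assay compound 4 gives only a limit, > 50 ug/mL, and its steps from compound 1, compound 2 and compound 3, all limits too, cannot be read. The compounds shown leave open whether the epoxide or the ethenyl linker gives the higher number.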